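A few compounds are considered here, and "the series" means these few. Any claim that something is new, unique, unknown or untested is made for them only; others in the source may bear on it.

Compound 1 `O=C(NO)c1ccc(CN(Cc2ccccc2)S(=O)(=O)c2cc(F)c(F)c(F)c2F)cc1` gives 5 nM in an assay on isolated protein for inhibition of protein deacetylase HDAC6 (Homo sapiens), read by mobility shift assay; a lower number here means a stronger inhibitor, a higher number a weaker inhibitor. Within the data shown here, compound 2 `O=C(NO)c1ccc(CN(Cc2ccc(F)cc2)S(=O)(=O)c2cc(F)c(F)c(F)c2F)cc1` gives 21 nM in this assay and so stands at the higher of the two numbers measured so far, with compound 1 its only neighbour, the step between them being a 4.2-fold higher number from compound 1 to compound 2 (0.62 log units; beyond the scatter). Compound 3 `O=C(NO)c1ccc(CN(Cc2cccc(F)c2)S(=O)(=O)c2cc(F)c(F)c(F)c2F)cc1` has not yet been measured in this assay. The change from compound 2 to compound 3 is 3-fluorophenyl in place of 4-fluorophenyl on a saturated chain carbon bound to a sulfonamide nitrogen. Among the measured compounds shown here, no measured step moves a fluorine from one place on this ring to another; the only step in hand, a 4.2-fold higher number from compound 1 to compound 2 (0.62 log units; beyond the scatter), puts a fluorine in for hydrogen on this ring and therefore bears on the present change only loosely, showing the size that a single fluorine on this ring has produced. The step from compound 2 to compound 3 is expected to be a 1.8-fold lower number from compound 2 to compound 3 (0.24 log units; within the scatter), small and uncertain in direction. Compound 3 is estimated at 12 nM, with a range of 4 nM to 35 nM.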

Compound 3, half-maximal inhibitory concentration: 14 nM
The estimate for compound 3 lay 1.2-fold (0.07 log units) below the measured number; low and high end bracket the measured number.
By their numbers in this assay, from the lowest: compound 1; then compounds 3 and 2 (each within the scatter of the next).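

In this assay moving the fluorine from 4-fluorophenyl to 3-fluorophenyl gives a 1.5-fold lower number from compound 2 to compound 3 (0.18 log units; within the scatter) and so these two placements on the ring cannot be told apart. Against the plain benzyl of compound 1, the 3-fluorobenzyl group gives a 2.8-fold higher number from compound 1 to compound 3 (0.45 log units; beyond the scatter) which shows that the higher number seen on adding fluorine is not confined to the 4-fluorobenzyl case, and none of the three compounds goes against this. Nothing at hand accounts for either step.

From the compounds shown here alone, whether a chloro, methoxy or amine group on this ring would track with fluorine remains open. Also open, going by these compounds, is how a longer chain, such as phenethyl in place of the benzyl on the sulfonamide nitrogen, would read in this assay.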